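This account rests on a few compounds, and the source may have more. Where it says the series, first, only, none or still open, it means among the compounds named here.

Measured in a functional assay on HepG2 cells (Homo sapiens) for antiproliferative activity, read by MTT assay, with a stated time of 72 h; a lower number here means a stronger inhibitor, a higher number a weaker inhibitor:
Compound 1 `O=C1C=C(N2CCN(c3ccccc3Cl)CC2)C(=O)c2ccccc21`: 11100 nM
Compound 2 `O=C1C=C(N2CCN(c3ccccc3Cl)CC2)C(=O)c2c(O)cccc21`: 7700 nM

Among the measured compounds shown here, compound 2 stands level with compound 1, its only neighbour on these numbers. For the measured compounds named here, the single measured step, a 1.4-fold lower number from compound 1 to compound 2 (0.16 log units; within the scatter), puts hydroxy in place of hydrogen on an aromatic carbon. Compound 3 `Cc1ccccc1N1CCN(C2=CC(=O)c3cccc(O)c3C2=O)CC1` keeps that hydroxy and differs from compound 2 elsewhere: methyl in place of chloro on an aromatic carbon. In words, this is methyl in place of chloro on an aromatic carbon, or 2-chlorophenyl to 2-methylphenyl. Going by the values given here, no measured step touches this place, so the data offer no direct guide to it. Among the compounds with values here, the one step available concerns a different change and stayed small, so on this thin evidence no step beyond the scatter is expected in this assay, in either direction. The expected step is a 1.0-fold higher number from compound 2 to compound 3 (0.02 log units; within the scatter). Compound 3 is estimated at 8000 nM, with an expected range of 3500 nM to 18000 nM.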

Compound 3, half-maximal inhibitory concentration: 10300 nM
Compound 3: the middle estimate sits 1.3-fold (0.11 log units) below what was measured; the range from low to high includes it.
By their numbers in this assay, from the lowest: compounds 2, 3 and 1 (each within the scatter of the next).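

In this assay, among the compounds shown here, the first measured change at this place, ortho to a large group on the aromatic ring, is 2-chlorophenyl to 2-methylphenyl, and it gives a 1.3-fold higher number from compound 2 to compound 3 (0.13 log units; within the scatter), so the two compounds stand level. With the hydroxy kept, this position therefore accepts methyl in place of chloro, one heavy atom for another, without a step beyond the scatter. Nothing among the available data bears on why the two stand level.

The compounds shown leave open whether a larger or different group at this place, such as methoxy, an amine or a carboxylic acid, would also stay level. They also leave open whether methyl in place of chloro reads the same on the core of compound 1, which lacks the hydroxy.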